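Methylamino to Ethylamino on Two Related Cores

The source may report more compounds than this note shows. Statements on the series, on what has been measured and on what is new or still open speak of the compounds shown alone.

Compound 1 `CNCC(=O)Nc1cc(OC)ccc1C(=O)c1ccc(OC)c2c1OC(C)(C)C=C2` and compound 3 `CCNCC(=O)Nc1cc(OC)ccc1C(=O)c1ccc(OC)c2c1OC(C)(C)C=C2` share one core and differ by methyl in place of hydrogen on a saturated chain carbon bound to an amine nitrogen. In a functional assay on A549 cells (Homo sapiens) for antiproliferative activity, read by MTT assay, with a stated time of 48 h (on this read-out higher numbers stand for weaker inhibition and lower numbers for stronger inhibition), compound 1 gives 620 nM, and compound 3 gives 1050 nM; the step is a 1.7-fold higher number from compound 1 to compound 3 (0.23 log units; within the scatter). Compound 2 `CNCC(=O)Nc1cc(OC)ccc1C(=O)c1ccc2c(c1)C=CC(C)(C)O2` carries a different core; the difference between the two cores is not broken down here. In this assay compound 2 gives 800 nM. Compound 4 `CCNCC(=O)Nc1cc(OC)ccc1C(=O)c1ccc2c(c1)C=CC(C)(C)O2` is not yet measured and differs from compound 2 by methyl in place of hydrogen on a saturated chain carbon bound to an amine nitrogen, the same kind of change as from compound 1 to compound 3, at the same place. For compound 4 the expected step is a 1.7-fold higher number from compound 2 to compound 4 (0.23 log units; within the scatter), because a 1.7-fold higher number from compound 1 to compound 3 (0.23 log units; within the scatter) was seen for the same kind of change on the other core. Compound 4 is therefore estimated at 1350 nM in this assay, with a likely range from 700 nM to 2800 nM.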

Compound 4, half-maximal inhibitory concentration: 1300 nM
Estimate against measurement, compound 4: 1.0-fold (0.02 log units) above; measured number inside the range.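

In this assay, replacing methylamino with ethylamino gave a 1.6-fold higher number from compound 2 to compound 4 (0.21 log units; within the scatter), and set beside the earlier step, the change reads alike on both cores: the same change on two cores in this assay, a 1.7-fold higher number (0.23 log units; within the scatter) from compound 1 to compound 3 and a 1.6-fold higher number (0.21 log units; within the scatter) from compound 2 to compound 4, 1.0-fold (0.02 log units) apart, within the scatter of two such steps. The size of the step therefore carried over from one core to the other, but each step lies within the scatter, so the agreement does not show a real difference between methylamino and ethylamino on either core. Two cores are also too few to show how the change would behave across the wider series.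

The compounds shown leave open what a longer chain such as propyl, or a branched one such as isopropyl, would give in place of ethyl. They also leave open how a primary amine or a cyclic amine such as pyrrolidine would compare on these two cores.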